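Moving the Hydroxyl Around the Pendant Phenyl Ring

This account rests on a few compounds, and the source may have more. Where it says the series, first, only, none or still open, it means among the compounds named here.

Among the measured compounds shown here, in a functional assay on T47D cells (Homo sapiens) for cytotoxicity, read by CCK-8 assay (on this read-out lower numbers stand for stronger inhibition and higher numbers for weaker inhibition), compound 3 `Oc1ccc(-c2cc(-c3ccco3)cc(-c3cccc(O)c3)n2)cc1` gives 1280 nM, placing it at the low end of the numbers so far, alongside compound 1 `Oc1ccc(-c2cc(-c3ccsc3)cc(-c3ccc(O)cc3)n2)cc1`, which gives 1770 nM in this assay, a gap within the scatter. Compound 2 `Oc1ccc(-c2cc(-c3ccco3)cc(-c3ccccc3O)n2)cc1` reaches only a limit of this assay, > 50000 nM. This limit, (the limit of > 50000 nM in this assay, at which 1 of the 3 values shown sits), is all that is known of compound 2. Shifting the hydroxyl gave an at least 39-fold lower number from compound 2 to compound 3 (1.59 log units; beyond the scatter). Compound 4 `Oc1ccc(-c2cc(-c3ccco3)cc(-c3ccc(O)cc3)n2)cc1` differs from compound 3 by 4-hydroxyphenyl in place of 3-hydroxyphenyl on an aromatic carbon, so that both pendant groups become 4-hydroxyphenyl, as in compound 1. For the measured compounds named here, the only measured step bearing on this change was the large one from 2-hydroxyphenyl to 3-hydroxyphenyl, while compound 3 sits within the scatter of compound 1, which carries 4-hydroxyphenyl and gives 1770 nM. The expected step is therefore a 1.2-fold higher number from compound 3 to compound 4 (0.07 log units; within the scatter). Compound 4 is estimated at 1500 nM, between 600 nM and 4000 nM.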

Compound 4, half-maximal inhibitory concentration: 21100 nM
Beside the measured number, compound 4's estimate is 14-fold (1.15 log units) below it, outside the stated range (above it).
By their numbers in this assay, from the lowest: compounds 3 and 1 (each within the scatter of the next); then compound 4. At a limit, above all of these: compound 2.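

In this assay, moving the hydroxyl once more gives a 16-fold higher number from compound 3 to compound 4 (1.22 log units; beyond the scatter), so the low number belongs to the 3-hydroxyphenyl group rather than to any move away from 2-hydroxyphenyl. The 4-hydroxyphenyl group still gives an at least 2.3-fold lower number from compound 2 to compound 4 (0.37 log units; beyond the scatter), a step read against a limit for compound 2. With 4-hydroxyphenyl in both compounds, the other ring also counts, giving a 12-fold higher number from compound 1 to compound 4 (1.08 log units; beyond the scatter).

The compounds shown leave open whether 3-hydroxyphenyl would also give the lowest number alongside thiophen-3-yl. As far as these compounds go, how a methoxy group or an amine in place of the hydroxyl would read also stays open.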